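Fluoro to chloro on the benzylsulfanyl arm of compound 2

A few compounds are considered here, and "the series" means these few. Any claim that something is new, unique, unknown or untested is made for them only; others in the source may bear on it.

Compound 1 `Cc1cc(Nc2cc(-c3ccccc3)[nH]n2)n2nc(SCCc3ccccc3)nc2n1` gives 2700 nM in a functional assay on MCF7 cells (Homo sapiens) for inhibition, read by MTT assay, with a stated time of 72 h; on this read-out lower numbers stand for stronger inhibition and higher numbers for weaker inhibition.
Compound 2 `Cc1cc(Nc2cc(-c3ccccc3)[nH]n2)n2nc(SCc3ccc(F)cc3)nc2n1` gives 4020 nM in this assay.
Compound 3 `Cc1cc(Nc2cc(-c3ccccc3)[nH]n2)n2nc(SCc3ccc(Br)cc3)nc2n1` gives 2720 nM in this assay.

Compound 2 holds the highest of the three numbers, but neither gap reaches beyond the scatter: a 1.5-fold higher number from compound 1 to compound 2 (0.17 log units; within the scatter), and against compound 3 the numbers are just as close. Compound 4 `Cc1cc(Nc2cc(-c3ccccc3)[nH]n2)n2nc(SCc3ccc(Cl)cc3)nc2n1` differs from compound 2 by chloro in place of fluoro on an aromatic carbon.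

Among the compounds with values here, the only measured step that bears directly on this change is the one between the two halogenated benzyl compounds, a 1.5-fold lower number from compound 2 to compound 3 (0.17 log units; within the scatter), itself within the scatter. The benzyl parent also sits level with the bromo compound, a 1.0-fold higher number from compound 1 to compound 3 (0.00 log units; within the scatter). Nothing here separates the three arm variants, so the fluoro-to-chloro swap is expected to leave the number where it is, a 1.3-fold lower number from compound 2 to compound 4 (0.10 log units; within the scatter), with no movement beyond the scatter in either direction.

Compound 4 is therefore estimated at 3200 nM in this assay, with a range from 1600 nM to 6400 nM.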

Compound 4, half-maximal inhibitory concentration: 8260 nM
Compound 4: the middle estimate sits 2.6-fold (0.41 log units) below what was measured, and the stated range ends below it.
By their numbers in this assay, from the lowest: compounds 1, 3 and 2 (each within the scatter of the next); then compound 4.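

In this assay, swapping one halogen for another on this aromatic carbon can move the number beyond the scatter: a 2.1-fold higher number from compound 2 to compound 4 (0.31 log units; beyond the scatter), and a 3.0-fold higher number from compound 3 to compound 4 (0.48 log units; beyond the scatter). The fluoro and bromo compounds remain within the scatter of each other, a 1.5-fold lower number from compound 2 to compound 3 (0.17 log units; within the scatter), so the 4-chlorobenzyl arm stands apart from both, and the number does not run in order from fluoro through chloro to bromo; it also separates from the arm of compound 1, a 3.1-fold higher number from compound 1 to compound 4 (0.49 log units; beyond the scatter), a gap that neither other halogenated arm showed. Nothing available accounts for why chloro stands apart from the other two halogens.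

From the compounds shown here alone, whether a methyl, a methoxy or an amine on this aromatic carbon would fall with chloro or with fluoro and bromo stays open. Also open, going by these compounds, is whether chloro gives the same step on the longer chain of compound 1.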